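The source may report more compounds than this note shows. Statements on the series, on what has been measured and on what is new or still open speak of the compounds shown alone.

Measured in an ADME assay on BJ cells (Homo sapiens), read by MTT assay, with a stated time of 72 h; on this read-out higher numbers stand for weaker inhibition and lower numbers for stronger inhibition:
- Compound 1 `COc1ncnc2c1c(-c1cc3ccccc3o1)cn2[C@@H]1O[C@H](CO)[C@@H](O)[C@H]1O`: 22400 nM
- Compound 2 `CN(C)c1ncnc2c1c(-c1ccoc1)cn2[C@@H]1O[C@H](CO)[C@@H](O)[C@H]1O`: 99200 nM
- Compound 3 `CN(C)c1ncnc2c1c(-c1ccsc1)cn2[C@@H]1O[C@H](CO)[C@@H](O)[C@H]1O`: > 100000 nM (a limit)

The reading for compound 3 is not a number but a limit, (the limit of > 100000 nM in this assay, at which 1 of the 3 values shown sits). Compound 4 `CN(C)c1ncnc2c1c(-c1cc3ccccc3o1)cn2[C@@H]1O[C@H](CO)[C@@H](O)[C@H]1O` carries 1-benzofuran-2-yl in place of thiophen-3-yl on an aromatic carbon. For the measured compounds named here, the only measured step, a number no lower from compound 2 to compound 3 (the limit leaves the size open), exchanges a different group, and its size cannot be read, so it offers little guidance. Compound 1 carries the same 1-benzofuran-2-yl group, differs elsewhere on the core, and gives 22400 nM. Resting on that value, stronger inhibition is expected in this assay. An estimated step of an at least 2.5-fold lower number from compound 3 to compound 4 (0.39 log units; beyond the scatter) is expected. Compound 4 is estimated at 40000 nM, with an expected range of 12000 nM to 100000 nM.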

Compound 4, half-maximal inhibitory concentration: > 100000 nM
Compound 4 ended at the assay's limit; the forecaster's own chance of this, stated with the estimate: 20%; at least 2.5-fold (0.39 log units) between middle value and limit.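

In this assay, the 1-benzofuran-2-yl group alone does not secure stronger inhibition: with it held in place, dimethylamino in place of methoxy gives an at least 4.4-fold higher number from compound 1 to compound 4 (0.64 log units; beyond the scatter). The reading at this position therefore depends on the other group on the shared core as well. 1-Benzofuran-2-yl in place of furan-3-yl gives a number no lower from compound 2 to compound 4 (the limit leaves the size open) and the size of this step cannot be read. The steps between compound 3 and the other two dimethylamino compounds cannot be read either, and compound 4, like compound 3, gives only a limit: the limit of > 100000 nM in this assay, at which 2 of the 4 values shown sit.

Going by these compounds, whether thiophen-3-yl or furan-3-yl would read differently alongside methoxy remains open. So does the effect of an amine or a carboxylic acid on this aromatic carbon.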